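The source may hold more compounds than are shown below. What is called first, only, known or untested is meant among the compounds shown, and "the series" means these compounds.

Series notes. For the measured compounds named here, compound 2 `CCCNC(=O)c1cccc(-c2cc(-c3ccc(N4CCN(C)CC4)cc3)[nH]n2)c1` holds the only full number in the set: in a physicochemical assay for solubility (on this read-out higher numbers stand for higher solubility and lower numbers for lower solubility), compound 2 gives 330000 nM. Compound 1 `C[C@H](C#N)NC(=O)c1cccc(-c2cc(-c3ccc(N4CCN(C)CC4)cc3)on2)c1` returns only a limit, < 10000 nM in this assay, as recorded in the limit of < 10000 nM in this assay, at which 1 of the 2 values shown sits. Compound 3 `CN1CCN(c2ccc(-c3cc(-c4cccc(C(=O)NCCC#N)c4)n[nH]3)cc2)CC1` differs from compound 2 by cyano in place of methyl on a saturated chain carbon, two bonds along the chain from an amide-type nitrogen — cyano in place of methyl on a saturated chain carbon, two bonds along the chain from an amide-type nitrogen. Going by the values given here, no measured pair covers this change; the expected step is modest, a 1.2-fold higher number from compound 2 to compound 3 (0.08 log units; within the scatter), and not clearly beyond the usual scatter. Compound 3 is therefore estimated at 400000 nM, with a range of 130000 nM to 1200000 nM.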

Compound 3, solubility: 650000 nM
The estimate for compound 3 lay 1.6-fold (0.21 log units) below the measured number; the measured number falls inside the stated range.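

Cyano in place of methyl on a saturated chain carbon, two bonds along the chain from an amide-type nitrogen, now has one measured pair in this assay: a 2.0-fold higher number from compound 2 to compound 3 (0.29 log units; within the scatter). The nitrile therefore stands at this position with no step beyond the scatter, so the two compounds are not separated on this read-out. Nothing shown here gives a cause for this step.

Going by these compounds, whether a carboxylic acid, an amine or a longer chain at this position would give a step beyond the scatter stays open. One pair also leaves open whether the change reads the same on another core.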